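The source may report more compounds than this note shows. Statements on the series, on what has been measured and on what is new or still open speak of the compounds shown alone.

Compound 3 `C/C(=N\Cc1ccccc1)c1c(O)c2cc([N+](=O)[O-])ccc2oc1=O` shows only a limit in an assay on isolated protein for inhibition of myosin-2 (Bos taurus), read by spectrophotometry, with a stated time of 24 min (on this read-out lower numbers stand for stronger inhibition and higher numbers for weaker inhibition), namely >= 100000 nM. Compound 1 `C/C(=N\CC1CCCCC1)c1c(O)c2ccccc2[nH]c1=O` likewise gives a limit in this assay, >= 100000 nM. Compound 3 therefore stands at the limit of >= 100000 nM in this assay, at which 2 of the 3 values shown sit. Compound 2 `CCCCC/N=C(\C)c1c(O)c2ccccc2oc1=O` gives 6700 nM in this assay, a number rather than a limit. Compound 4 `CCCCC/N=C(\C)c1c(O)c2cc([N+](=O)[O-])ccc2oc1=O` has not been measured; it differs from compound 3 by butyl in place of phenyl on a saturated chain carbon bound to a double-bonded nitrogen. Going by the values given here, no measured pair of compounds shares exactly this change, so the size of the step is open. The butyl chain of compound 4 is also present in compound 2, which gives 6700 nM, so a number, rather than a limit, might be reached. In this assay the expected step is an at least 3.3-fold lower number from compound 3 to compound 4 (0.52 log units; beyond the scatter), towards stronger inhibition. Compound 4 is estimated at 30000 nM, within 6000 nM to 100000 nM.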

Compound 4, half-maximal inhibitory concentration: >= 100000 nM
Compound 4 gave a limit, no number; the forecaster's own chance of this, stated with the estimate: 45%; middle value at least 3.3-fold (0.52 log units) away from the limit.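

Nitro in place of hydrogen on an aromatic carbon gives an at least 14-fold higher number from compound 2 to compound 4 (1.17 log units; beyond the scatter) in this assay, so this one change turns a measured number into a limit. Butyl in place of phenyl does not bring the nitro-bearing compounds back to a number, and the step between those two limits cannot be read. Most of the compounds now sit at the same limit: the limit of >= 100000 nM in this assay, at which 3 of the 4 values shown sit.

Going by these compounds, how far compound 3 and compound 4 lie beyond that limit remains unknown. On these data alone, whether a methoxy group or an amine in place of nitro would preserve a measurable number also remains open.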